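Solubility notes: compound 2 to compound 3

The source may hold more compounds than are shown below. What is called first, only, known or untested is meant among the compounds shown, and "the series" means these compounds.

Of the compounds shown here, two have been measured in a physicochemical assay for solubility, read by HPLC; on this read-out lower numbers stand for lower solubility and higher numbers for higher solubility. Compound 1 `O=C(C1CC1)N1CCN(c2nc(=O)c3cc(C(F)(F)F)cc([N+](=O)[O-])c3s2)CC1` gives 52.9 ug/mL, and compound 2 `CCC(=O)N1CCN(c2nc(=O)c3cc(C(F)(F)F)cc([N+](=O)[O-])c3s2)CC1` gives 3.29 ug/mL. Among the measured compounds shown here, compound 2 therefore stands lowest of the two numbers; the one step in hand, a 16-fold lower number from compound 1 to compound 2 (1.21 log units; beyond the scatter), is ethyl in place of cyclopropyl on a carbonyl carbon.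

Compound 3 `CC(C)(C)C1CCC(C(=O)N2CCN(c3nc(=O)c4cc(C(F)(F)F)cc([N+](=O)[O-])c4s3)CC2)CC1` is not yet measured. It differs from compound 2 by 4-(tert-butyl)cyclohexyl in place of ethyl on a carbonyl carbon. For the measured compounds named here, no measured step involves this entering group, so the single step from compound 1 to compound 2 bears on it only loosely: it shows that an exchange at this carbonyl carbon can move this assay by a large amount, but it does not fix the direction for a ring of this kind with a tert-butyl substituent. Compound 2 already sits at the low end of the two numbers.

The working expectation for compound 3 is a further fall in this assay, a 3.3-fold lower number from compound 2 to compound 3 (0.52 log units; beyond the scatter), with a wide margin for the unknown direction. Compound 3 is estimated at 1 ug/mL, in a range from 0.2 ug/mL to 6 ug/mL.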

Compound 3, solubility: < 0.1 ug/mL
Compound 3 ended at the assay's limit; the forecaster's own chance of this, stated with the estimate: 25%; at least 10-fold (1.00 log units) between middle value and limit.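

In this assay, the exchange on the carbonyl carbon is now seen with a far bigger group, and 4-(tert-butyl)cyclohexyl in place of ethyl gives an at least 32-fold lower number from compound 2 to compound 3 (1.51 log units; beyond the scatter), while in place of cyclopropyl it gives an at least 520-fold lower number from compound 1 to compound 3 (2.72 log units; beyond the scatter). The earlier pair showed only that this position can move the read-out, whereas the three compounds now show that a carbon ring here does not by itself go with the higher number: cyclopropyl in compound 1 and 4-(tert-butyl)cyclohexyl in compound 3 sit at opposite ends, with ethyl in compound 2 between them. The value of compound 3 is a limit and not a number, so both steps give only a minimum size: the limit of < 0.1 ug/mL in this assay, at which 1 of the 3 values shown sits.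

The compounds shown do not separate the contribution of the tert-butyl substituent from that of the cyclohexyl ring, and how far compound 3 lies past the limit stays unknown. As far as these compounds go, how an amine or a carboxylic acid on the cyclohexyl ring, or a longer chain in place of ethyl, would read in this assay also remains open.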